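A few compounds are considered here, and "the series" means these few. Any claim that something is new, unique, unknown or untested is made for them only; others in the source may bear on it.

Three compounds from a single series have been run in a functional assay on Ehrlich cells (Mus musculus) for cytotoxicity, read by trypan blue exclusion, with a stated time of 2 h, tested at 10 ug/mL; a lower number here means a weaker effect, a higher number a stronger effect of the compound at the concentration tested. Compound 1, with the structure `N#CC1=C(NC(=O)C2CC2)N(c2ccc(S(N)(=O)=O)cc2)C2=C(C(=O)CCC2)C1c1ccc(Cl)cc1Cl`, gives 20%. Compound 2, `NC(=O)C1=C(N)N(c2ccc(S(N)(=O)=O)cc2)C2=C(C(=O)CCC2)C1c1ccc(Cl)cc1Cl`, gives 30%, and compound 3, `N#CC1=C(/N=C/c2ccc([N+](=O)[O-])cc2[N+](=O)[O-])N(c2ccc(S(N)(=O)=O)cc2)C2=C(C(=O)CCC2)C1c1ccc(Cl)cc1Cl`, gives 10%. On these three numbers compound 1 stands second highest, yet its gap to compound 2 and its gap to compound 3 both lie within the usual scatter of this kind of measurement, so nothing can be ordered among them.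

Compound 4, `CC(=O)CC(=O)NC1=C(C#N)C(c2ccc(Cl)cc2Cl)C2=C(CCCC2=O)N1c1ccc(S(N)(=O)=O)cc1`, has not yet been measured in this assay. It differs from compound 1 in one place: 2-oxopropyl in place of cyclopropyl on a carbonyl carbon. The change sits on a carbonyl carbon whose other neighbour is an amide-type nitrogen, so the shared core of compound 1 is kept and only the group on that carbonyl changes.

For the measured compounds named here, no step between two measured compounds of this set isolates such a change, and the three measured numbers themselves all sit within the scatter of one another. The step from compound 1 to compound 4 is therefore expected to be no change at the digits printed from compound 1 to compound 4 (within the scatter), that is, no change beyond the scatter. Compound 4 is estimated to give 20% in this assay, with a range from 5% to 35%.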

Compound 4, a percentage reported as activity, at one concentration (the size of the read-out at that concentration, not a potency): 40%
Beside the measured number, compound 4's estimate is 20 percentage points below it; measured number outside the range, above it.
By their numbers in this assay, from the lowest: compounds 3, 1, 2 and 4 (each within the scatter of the next, the first and the last beyond it).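

For the compounds shown here, the group on this carbonyl carbon does register in this assay: putting 2-oxopropyl in place of cyclopropyl gives a number 20 percentage points higher from compound 1 to compound 4 (beyond the scatter), the only single-place step in this set and one that lies beyond the scatter. The swap replaces a three-membered carbon ring with an open chain and adds an oxygen that counts as a hydrogen-bond acceptor, and this one step cannot separate those two differences. No supporting measurement is available to explain the step.

A propyl chain on the same carbonyl carbon, which is open but has no oxygen, would help separate the loss of the ring from the gain of the ketone. On these data alone, it also remains open how a carboxylic acid or an amine in that chain would read in this assay.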